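Removing the Bromo Group from a Fused-Ring Aromatic Series

The source may hold more compounds than are shown below. What is called first, only, known or untested is meant among the compounds shown, and "the series" means these compounds.

Measured compounds:
compound 1, `CSc1ccccc1-c1nc2ncccc2o1`: 21%
compound 2, `Clc1cccc(-c2nc3ncccc3o2)c1`: 32%
compound 3, `Brc1ccccc1-c1nc2ncccc2o1`: 24%

All three compounds share the same fused core and differ only in the group on the attached benzene ring. In a functional assay on the whole organism for inhibition, with Rattus norvegicus as the target, at a dose of 30 mg/kg (on this read-out higher numbers stand for more inhibition at the one dose given (going by the name of the read-out) and lower numbers for less inhibition), compound 3 gives 24%, which places it second of the three numbers; yet its gap to compound 1 and its gap to compound 2 both fall within the scatter, so the three compounds cannot be told apart on this read-out.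

Compound 4, `c1ccc(-c2nc3ncccc3o2)cc1`, is not yet measured. It differs from compound 3 by hydrogen in place of bromo on an aromatic carbon.

For the measured compounds named here, only one measured step touches the same position: a number 3 percentage points higher from compound 1 to compound 3 (within the scatter), a change that left the read-out essentially unmoved. Swapping one group for another at that place did nothing beyond the scatter, and the other two compounds agree. The expectation is therefore that compound 4 shows no step beyond the scatter, with no change at the digits printed from compound 3 to compound 4 (within the scatter). The estimate for compound 4 in this assay is 24%, ranging from 10% to 40%.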

Compound 4, a percentage reported as inhibition, in the whole organism at one dose (the size of the read-out at that dose, not a potency): 41%
Estimate against measurement, compound 4: 17 percentage points below; measured number above the stated range.
By their numbers in this assay, from the lowest: compounds 1, 3, 2 and 4 (each within the scatter of the next, the first and the last beyond it).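

In this assay, replacing a group with hydrogen on this aromatic carbon shows what swapping one group for another did not: removing bromo gives a number 17 percentage points higher from compound 3 to compound 4 (beyond the scatter), and removing methylsulfanyl gives a number 20 percentage points higher from compound 1 to compound 4 (beyond the scatter). The chloro compound does not separate in the same way: the change to hydrogen gives a number 9 percentage points higher from compound 2 to compound 4 (within the scatter), so hydrogen and chloro cannot be told apart on this read-out. Nothing shown gives a measured reason for these steps.

Going by these compounds, whether an amine, a carboxylic acid or a longer chain on this ring would read closer to compound 4 or closer to compound 3 remains open. With a single dose, these numbers also leave open how the compounds would compare at other doses.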